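The compounds below may be only part of what the source reports. "The series", "measured", "known", "first", "only" and "open" are said of these compounds alone.

Measured compounds:
compound 1 `CNc1cc(Oc2ccc(NC(=O)Nc3ccccc3)cc2)ncn1`, 6300 nM
compound 2 `Cc1cc(Oc2ccc(NC(=O)Nc3cccc(C(F)(F)F)c3)cc2)ncn1`, 160 nM

In an assay on isolated protein for inhibition of serine/threonine-protein kinase TNNI3K (Homo sapiens) (on this read-out lower numbers stand for stronger inhibition and higher numbers for weaker inhibition), compound 1 gives 6300 nM, the highest of the two numbers, so the weaker inhibitor of the pair. Compound 2 gives 160 nM; its gap from compound 1 lies well beyond the scatter, but compound 2 differs from compound 1 in two places at once, so nothing can be read off for either change alone.

Compound 3 `CCc1cccc(NC(=O)Nc2ccc(Oc3cc(NC)ncn3)cc2)c1` is the unmeasured compound. It differs from compound 1 in one place: ethyl in place of hydrogen on an aromatic carbon, meta to a large group. Within the data shown here, no step between measured compounds isolates this change. Because compound 2, which carries a group at this same place, gives 160 nM, the step from compound 1 to compound 3 is expected to lower the number, with a 4.2-fold lower number from compound 1 to compound 3 (0.62 log units; beyond the scatter) as the estimated size. Compound 3 is therefore expected to give about 1500 nM in this assay, within 400 nM to 5000 nM.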

Compound 3, half-maximal inhibitory concentration: 200 nM
The estimate for compound 3 lay 7.5-fold (0.88 log units) above the measured number, outside the stated range (below it).
By their numbers in this assay, from the lowest: compounds 2 and 3 (each within the scatter of the next); then compound 1.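

In this assay, ethyl in place of hydrogen on an aromatic carbon, meta to a large group, gives a 32-fold lower number from compound 1 to compound 3 (1.50 log units; beyond the scatter) with nothing else in the core of compound 1 altered. The earlier pair changed two places at once, whereas this single change shows that a group at this place can by itself shift the number by a large step, and that ethyl, with no ring and no hydrogen-bond donor or acceptor, is enough for this. Nothing in the data shown accounts for the size of this step.

Going by these compounds, what methyl, propyl or an amine would do at this same place remains open, as does how trifluoromethyl would compare with ethyl on the core of compound 1. Also open, on these data alone, is what methylamino contributes on its own, as its exchange for methyl in compound 2 comes together with the trifluoromethyl change.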